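This account rests on a few compounds, and the source may have more. Where it says the series, first, only, none or still open, it means among the compounds named here.

Measured so far in a functional assay on HCT-116 cells (Homo sapiens) for antiproliferative activity, read by MTT assay, with a stated time of 24 h; a higher number here means a weaker inhibitor, a lower number a stronger inhibitor:
compound 1 `COc1cc(OC)c(-c2coc3cc(OCC=C(C)C)ccc3c2=O)cc1OC` gives 680 nM
compound 2 `COc1ccc2c(=O)c(-c3cc(OC)c(OC)cc3OC)coc2c1` gives 9170 nM

Going by the values given here, compound 2 stands at the highest of the two numbers in this assay; its only neighbour, compound 1, is the step of a 13-fold higher number from compound 1 to compound 2 (1.13 log units; beyond the scatter) away, which is beyond the scatter. Among the compounds with values here, that step is the sole comparison in the set, and it shows that taking away the 2-methylprop-1-en-1-yl on a saturated chain carbon bound to an oxygen on an aromatic ring weakened the inhibitor markedly.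

Compound 3 `COc1cc(OC)c(-c2coc3cc(OCc4ccccc4F)ccc3c2=O)cc1OC` is not yet measured. It differs from compound 2 by 2-fluorophenyl in place of hydrogen on a saturated chain carbon bound to an oxygen on an aromatic ring. The change works at the same place as the step from compound 1 to compound 2, but in the opposite sense: a heavier group is put back on the saturated chain carbon bound to an oxygen on an aromatic ring. The step from compound 1 to compound 2 is therefore the one that bears on it, and it was large.

On that basis compound 3 is expected to give a lower number than compound 2, with a step of about an 11-fold lower number from compound 2 to compound 3 (1.06 log units; beyond the scatter), bringing it back near compound 1. The estimate for compound 3 in this assay is 800 nM, within 250 nM to 3000 nM.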

Compound 3, half-maximal inhibitory concentration: 2900 nM
For compound 3 the middle estimate is 3.6-fold (0.56 log units) below the measured one; measured number inside the range.
By their numbers in this assay, from the lowest: compound 1; then compound 3; then compound 2.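

In this assay, going by these compounds alone, the earlier pair showed only that one group, 2-methylprop-1-en-1-yl, could not be replaced by hydrogen on the saturated chain carbon bound to an oxygen on an aromatic ring without a large loss; a 2-fluorophenyl at the same place also gives a gain over hydrogen, with a 3.2-fold lower number from compound 2 to compound 3 (0.50 log units; beyond the scatter) in this read-out, so the gain is not tied to that one group. The size of the gain does depend on the group, however: exchanging the two groups gives a 4.3-fold higher number from compound 1 to compound 3 (0.63 log units; beyond the scatter) in the same read-out, and the 2-methylprop-1-en-1-yl remains the better of the two at this place. Nothing in hand explains why the two groups differ.

Open, going by these compounds, is where a plain phenyl without the fluorine, a longer saturated chain, or a chain ending in an amine would fall relative to these two groups at this place. Also open, on these data alone, is whether the order of the three compounds carries over to cells other than the ones used here.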